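Removing the methoxy group: compound 3 to compound 4

A few compounds are considered here, and "the series" means these few. Any claim that something is new, unique, unknown or untested is made for them only; others in the source may bear on it.

Three compounds share a common core and were tested in a functional assay on B16-F10 cells (Mus musculus) for cytotoxicity, read by MTT assay, with a stated time of 48 h; on this read-out lower numbers stand for stronger inhibition and higher numbers for weaker inhibition. Compound 1 `O=C(/C=C\Nc1cnc2ccccc2c1)c1nc(-c2ccccc2)n2ccccc12` gives 3780 nM in this assay. Compound 2 `COc1ccc(N/C=C\C(=O)c2nc(-c3ccc(F)cc3)n3ccccc23)cc1` gives 2560 nM. Compound 3 `COc1ccc(N/C=C\C(=O)c2nc(-c3ccc(OC)cc3)n3ccccc23)cc1` gives 2120 nM, the lowest of the three numbers, though compound 2 sits only a 1.2-fold lower number from compound 2 to compound 3 (0.08 log units; within the scatter) away, and the gap to compound 1 also lies within the scatter, so no ranking among them can be claimed.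

Compound 4 `COc1ccc(N/C=C\C(=O)c2nc(-c3ccccc3)n3ccccc23)cc1` has not yet been measured. It differs from compound 3 in one place: hydrogen in place of methoxy on an aromatic carbon, on an aromatic carbon of a six-membered aromatic ring of carbon only, para to a large group. For the measured compounds named here, the only single step on record in this ring, a 1.2-fold lower number from compound 2 to compound 3 (0.08 log units; within the scatter), swapped fluoro for methoxy and stayed within the scatter. Compound 1 carries a plain phenyl at the same position but differs from compound 3 elsewhere too, so its value cannot be read as a single step. With so little movement across the set, compound 4 is expected to shift by a 1.2-fold higher number from compound 3 to compound 4 (0.07 log units; within the scatter), which is no change beyond the scatter. The estimate for compound 4 is therefore 2500 nM, in a range from 1200 nM to 5200 nM.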

Compound 4, half-maximal inhibitory concentration: 1790 nM
Compound 4: the middle estimate sits 1.4-fold (0.15 log units) above what was measured; the range from low to high includes it.
By their numbers in this assay, from the lowest: compounds 4, 3, 2 and 1 (each within the scatter of the next, the first and the last beyond it).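

In this assay, hydrogen in place of methoxy on this aromatic carbon, para to a large group, stays within the scatter (a 1.2-fold lower number from compound 3 to compound 4 (0.07 log units; within the scatter)), and so does hydrogen in place of fluoro (a 1.4-fold lower number from compound 2 to compound 4 (0.16 log units; within the scatter)), so hydrogen, fluoro and methoxy cannot be told apart at this position. Compound 4 also opens a single-change comparison at the amine nitrogen: with the plain phenyl shared, 4-methoxyphenyl in place of quinolin-3-yl gives a modest step (a 2.1-fold lower number from compound 1 to compound 4 (0.32 log units; beyond the scatter)), the only new one beyond the scatter. No evidence is available that bears on these results.

Going by these compounds, whether an amine, a carboxylic acid or a longer chain such as butoxy on the same aromatic carbon would move the number beyond the scatter remains open. So does how a plain phenyl on the amine nitrogen would compare with 4-methoxyphenyl and quinolin-3-yl.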